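Series notes: a methyl on the anilino ring

The source may report more compounds than this note shows. Statements on the series, on what has been measured and on what is new or still open speak of the compounds shown alone.

Measured so far, all in a functional assay on Bel-7402 cells (Homo sapiens) for cytotoxicity, read by MTT assay; a lower number here means a stronger inhibitor, a higher number a weaker inhibitor:
- compound 1, `COc1cccc(/C=C/C(=O)c2sc(Nc3ccccc3)nc2C)c1`, a limit only: > 25000 nM
- compound 2, `Cc1nc(Nc2ccccc2)sc1C(=O)/C=C/c1ccccc1`, a limit only: > 25000 nM
- compound 3, `Cc1nc(Nc2ccccc2)sc1C(=O)/C=C/c1ccccc1Cl`, a limit only: > 25000 nM

Compound 1 stands nowhere on a numerical scale: in this assay its result is a limit and not a number. The same holds for its two neighbours, so that the whole set sits at the limit of > 25000 nM in this assay, at which 3 of the 3 values shown sit. Consequently every step between the measured compounds is unreadable: a step that the two limits leave unreadable from compound 1 to compound 2, a step that the two limits leave unreadable from compound 1 to compound 3 and a step that the two limits leave unreadable from compound 2 to compound 3 all run from one limit to another, and their size cannot be taken from the data.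

Compound 4, `COc1cccc(/C=C/C(=O)c2sc(Nc3ccc(C)cc3)nc2C)c1`, is the next member. It differs from compound 1 by methyl in place of hydrogen on an aromatic carbon. Going by the values given here, none of the measured steps touches the anilino ring; all three change the phenyl on the double-bonded chain. They therefore bear on the new step only in one way: so far no change anywhere in the series has brought a value out of the limit. No direction and no size can be read for the step from compound 1 to compound 4 beyond the scatter.

The estimate for compound 4 is therefore 35000 nM, within 10000 nM to 120000 nM, which would mean a step that the limit leaves unreadable from compound 1 to compound 4, most probably reported again as a limit.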

Compound 4, half-maximal inhibitory concentration: > 25000 nM
Compound 4 was reported as a limit; the forecaster's own chance of this, stated with the estimate: 85%; the middle value lies beyond the limit too.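

No new step can be read: compound 4 and compound 1 are both limits and not numbers in this assay, and the whole series now sits at one reading: the limit of > 25000 nM in this assay, at which 4 of the 4 values shown sit.

The compounds shown leave open whether any change on the anilino ring or the chain phenyl brings a value out of the limit.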